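The source may report more compounds than this note shows. Statements on the series, on what has been measured and on what is new or still open speak of the compounds shown alone.

Compound 1 `COCC1CN(S(=O)(=O)c2ccc(F)cc2)CCN1C(C)=O` gives >= 4 h in an ADME assay on a cell-free system (plasma, Rattus norvegicus, strain Sprague-Dawley) for metabolic stability, read by LC-MS, tested at 1 uM; a lower number here means that the compound disappears faster, a higher number that the compound lasts longer.
Compound 2 `CC(=O)N1CCN(S(=O)(=O)c2ccc(F)cc2)CC1` gives >= 4 h in this assay.

The value of compound 1 is a limit of the assay, not a number. The value of compound 2 is likewise a limit. For the measured compounds named here, compound 2 therefore stands at the limit of >= 4 h in this assay, at which 2 of the 2 values shown sit, and the one measured step, a step that the two limits leave unreadable from compound 1 to compound 2, cannot be read. Compound 3 `CCOC(=O)C1CN(C(C)=O)CCN1S(=O)(=O)c1ccc(F)cc1` differs from compound 2 by ethoxycarbonyl in place of hydrogen on a saturated ring carbon. Going by the values given here, no measured step bears on this change, so no size or direction can be drawn from the data. Compound 3 is estimated at 1.5 h in this assay, between 0.3 h and 4 h. That estimate is expected to mean a step of an at least 2.6-fold lower number from compound 2 to compound 3 (0.42 log units; beyond the scatter).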

Compound 3, half-life: 0.35 h
Beside the measured number, compound 3's estimate is 4.3-fold (0.63 log units) above it; the measured number falls inside the stated range.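

For the compounds shown here, with ethoxycarbonyl in place of hydrogen on a saturated ring carbon, next to the ring nitrogen, this assay gives the first readable step: an at least 11-fold lower number from compound 2 to compound 3 (1.05 log units; beyond the scatter). The step between compound 1 and compound 2 cannot be read, since both values are limits. Compound 3 alone stands off the limit shared by the others: the limit of >= 4 h in this assay, at which 2 of the 3 values shown sit.

From the compounds shown here alone, whether a methyl or a carboxylic acid on this same ring carbon would give a step of like size stays open. So does the question of how long compound 2 actually lasts.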